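Removing a ring chloro from a diaryl urea series

The source may report more compounds than this note shows. Statements on the series, on what has been measured and on what is new or still open speak of the compounds shown alone.

Measured compounds:
- compound 1, `Cc1ccc(NC(=O)Nc2nnc(Sc3ncnc4scc(-c5ccncc5)c34)s2)cc1Cl`: 16000 nM
- compound 2, `Cc1ccc(NC(=O)Nc2nnc(Sc3ncnc4scc(-c5ccncc5)c34)s2)cc1`: 52000 nM
- compound 3, `O=C(Nc1ccc(Cl)c(Cl)c1)Nc1nnc(Sc2ncnc3scc(-c4ccncc4)c23)s1`: 61900 nM

All three share a core and differ only in the aryl group on the urea. In a functional assay on HepG2 cells (Homo sapiens) for antiproliferative activity, read by MTT assay, with a stated time of 48 h (on this read-out lower numbers stand for stronger inhibition and higher numbers for weaker inhibition), compound 1 gives 16000 nM, and hydrogen in place of chloro on an aromatic carbon brings a 3.3-fold higher number from compound 1 to compound 2 (0.51 log units; beyond the scatter). The cores of compound 1 and compound 3 differ by chloro in place of methyl on an aromatic carbon, which brings a 3.9-fold higher number from compound 1 to compound 3 (0.59 log units; beyond the scatter). Between compound 2 and compound 3 the step is a 1.2-fold higher number from compound 2 to compound 3 (0.08 log units; within the scatter), so these two cannot be ranked against each other.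

Compound 4, `O=C(Nc1ccc(Cl)cc1)Nc1nnc(Sc2ncnc3scc(-c4ccncc4)c23)s1`, has not been measured. It differs from compound 3 by hydrogen in place of chloro on an aromatic carbon. Among the compounds with values here, this is the same kind of change as the one from compound 1 to compound 2, not the same one: in compound 1 the departing chloro sits ortho to a methyl group, whereas in compound 3 it sits ortho to a chloro group, while in both it is meta to a large group. Within the data shown here, since the one measured example of this kind of change, a 3.3-fold higher number from compound 1 to compound 2 (0.51 log units; beyond the scatter), gave a clearly higher number, the expectation for compound 4 is a step of a 2.1-fold higher number from compound 3 to compound 4 (0.32 log units; beyond the scatter), a weakening of similar size. The estimate for compound 4 in this assay is therefore 130000 nM, expected to lie between 50000 nM and 350000 nM.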

Compound 4, half-maximal inhibitory concentration: 28900 nM
Beside the measured number, compound 4's estimate is 4.5-fold (0.65 log units) above it; the whole stated range lies above it.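

In this assay, taking away the same ring chloro that weakened compound 1 now gives a 2.1-fold lower number from compound 3 to compound 4 (0.33 log units; beyond the scatter), so the step runs the opposite way on the two cores and does not carry over: the same change on two cores in this assay, a 3.3-fold higher number (0.51 log units; beyond the scatter) from compound 1 to compound 2 and a 2.1-fold lower number (0.33 log units; beyond the scatter) from compound 3 to compound 4, 7.0-fold (0.84 log units) apart, beyond the scatter of two such steps. Swapping methyl for chloro does not carry over either, since a 1.8-fold lower number from compound 2 to compound 4 (0.26 log units; within the scatter) is a much smaller step than the one seen on the other pair of compounds: the same change on two cores in this assay, a 3.9-fold higher number (0.59 log units; beyond the scatter) from compound 1 to compound 3 and a 1.8-fold lower number (0.26 log units; within the scatter) from compound 2 to compound 4, 7.0-fold (0.84 log units) apart, beyond the scatter of two such steps. The third new step, a 1.8-fold higher number from compound 1 to compound 4 (0.26 log units; within the scatter), leaves that pair unranked, and the two comparisons together show that a step measured on one aryl group cannot simply be transferred to another in this series, although they rest on just two pairs of steps and do not show why the outcomes differ.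

The compounds shown leave open whether the reversal is particular to chloro, or whether a fluoro or methoxy group in the place of the departing chloro would follow compound 1 or compound 3. A phenyl ring carrying no substituent at all would also help to show what the remaining chloro or methyl group contributes on its own.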